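Adding a Chloro to a Compound With No Measurable Effect

The source may hold more compounds than are shown below. What is called first, only, known or untested is meant among the compounds shown, and "the series" means these compounds.

Three compounds were tested in a functional assay on LS174T cells (Homo sapiens) for cytotoxicity, read by MTT assay, with a stated time of 72 h; a higher number here means a weaker inhibitor, a lower number a stronger inhibitor. Compound 1 `COCOc1cc(/C=C/C(=O)OCC(=O)Nc2ccc(Cl)cc2)ccc1OCc1ccccc1` gives only a limit of the assay, > 200000 nM. Compound 2 `CCOc1ccc(COc2c(OC)cc(/C=C/C(=O)N3CCN(Cc4ccc(Cl)c(Cl)c4)CC3)cc2OC)cc1` likewise gives only a limit, > 200000 nM. Compound 3 `COc1ccc(/C=C/C(=O)OCC(=O)Nc2ccccc2)cc1OC` also stops at a limit, > 200000 nM. So compound 3 stands exactly where every value shown stands, at the limit of > 200000 nM in this assay, at which 3 of the 3 values shown sit, with no number to set it apart from the others. Compound 4 `COc1ccc(/C=C/C(=O)OCC(=O)Nc2ccc(Cl)cc2)cc1OC` differs from compound 3 by chloro in place of hydrogen on an aromatic carbon. Compound 1 already carries a (4-chlorophenyl)amino group and gives > 200000 nM, itself a limit. Compound 4 is therefore expected to show no change beyond the scatter, the step being a number no higher from compound 3 to compound 4 (the limit leaves the size open). The estimate for compound 4 is 200000 nM, expected between 60000 nM and 200000 nM.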

Compound 4, half-maximal inhibitory concentration: > 200000 nM
Compound 4: only a limit was reported (the forecaster's own chance of this, stated with the estimate: 85%); the middle value sits exactly at the limit.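

Compound 3 and compound 4 each give only a limit of the assay, so the step between them cannot be read. Among these compounds, with no compound here giving an actual number, whether this chloro changes potency at all remains open.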